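Methoxy for methyl in a furanylmethyl aminoquinazoline series

The compounds below may be only part of what the source reports. "The series", "measured", "known", "first", "only" and "open" are said of these compounds alone.

Measured so far:
- compound 1, `Cc1cccc2c(NCc3ccco3)nc(NC(C)C)nc12`: 666 10^-6 cm/s
- compound 2, `Cc1ccc2c(NCc3ccco3)nc(NC(C)C)nc2c1`: 798 10^-6 cm/s
- compound 3, `COc1cccc2c(NCc3ccco3)nc(NC(C)C)nc12`: 1060 10^-6 cm/s

Of the compounds shown here, three built on the same core have been tested in a physicochemical assay for permeability, using PAMPA, at pH 7.4; a higher number here means that the compound crosses the layer faster, a lower number that the compound crosses the layer more slowly. Compound 1 and compound 2 carry the same atoms joined differently; how the two cores differ is not broken down here. Compound 3 is compound 1 with one change, (methoxy in place of methyl on an aromatic carbon), and that change gave a 1.6-fold higher number from compound 1 to compound 3 (0.20 log units; within the scatter). Compound 2 sits between the other two, and its gaps to compound 1 and to compound 3 both lie within the scatter, so the three values cannot be told apart with confidence.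

The compound not yet measured is compound 4, `COc1ccc2c(NCc3ccco3)nc(NC(C)C)nc2c1`. It arises from compound 2 by methoxy in place of methyl on an aromatic carbon. Going by the values given here, this is the same kind of change as the one from compound 1 to compound 3, though the place is not the same: in compound 3 the methoxy sits ortho to a fused ring and meta to a fused ring, whereas in compound 4 it sits meta to a fused ring and para to a fused ring.

The expected step from compound 2 to compound 4 in this assay is a 1.3-fold higher number from compound 2 to compound 4 (0.10 log units; within the scatter), a guess resting on the earlier change because it gave a 1.6-fold higher number from compound 1 to compound 3 (0.20 log units; within the scatter), a shift within the scatter. Compound 4 is therefore estimated at 1000 10^-6 cm/s, with a likely range from 650 10^-6 cm/s to 1600 10^-6 cm/s.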

Compound 4, apparent permeability: 1330 10^-6 cm/s
Beside the measured number, compound 4's estimate is 1.3-fold (0.12 log units) below it; the measured number falls inside the stated range.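

In this assay, methoxy in place of methyl on an aromatic carbon gave a 1.7-fold higher number from compound 2 to compound 4 (0.22 log units; within the scatter) on this core and a 1.6-fold higher number from compound 1 to compound 3 (0.20 log units; within the scatter) on the other core. Both steps point the same way even though the methoxy sits at a different place on each core, which fits the idea that the change carries from one core to the other, yet each step lies within the scatter, so neither pair shows a real effect on its own and two pairs cannot establish a rule for the series. No measurement is at hand that could explain these numbers, so no reason can be offered for either step.

The compounds shown hold only methyl and methoxy at these places on the shared core, so it remains open whether a clearly different group there, such as an amine, a carboxylic acid or a longer chain, would move the number beyond the scatter. Also open, from the compounds shown here alone, is whether the swap would behave alike with something other than the furanylmethyl side chain, or in any read-out other than this assay.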